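Replacing the Nitro Group of Compound 3 with Cyano

A few compounds are considered here, and "the series" means these few. Any claim that something is new, unique, unknown or untested is made for them only; others in the source may bear on it.

Compound 1 `COc1ccc(S(=O)(=O)Nc2ccc(Cl)c3cc[nH]c23)cc1`: 0.92 ug/mL
Compound 2 `O=S(=O)(Nc1ccc(Cl)c2cc[nH]c12)c1ccc(Cl)cc1`: 9.7 ug/mL
Compound 3 `O=[N+]([O-])c1ccc(S(=O)(=O)Nc2ccc(Cl)c3cc[nH]c23)cc1`: 9.1 ug/mL

All three values come from a functional assay on KB cells (Homo sapiens) for antiproliferative activity, read by colorimetric assay and MTT assay; a lower number here means a stronger inhibitor, a higher number a weaker inhibitor. Compound 3 stands level with compound 2, with a 1.1-fold lower number from compound 2 to compound 3 (0.03 log units; within the scatter). Compound 1 stands well apart from both, with an 11-fold higher number from compound 1 to compound 2 (1.02 log units; beyond the scatter) and a 9.9-fold higher number from compound 1 to compound 3 (1.00 log units; beyond the scatter).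

Compound 4 `N#Cc1ccc(S(=O)(=O)Nc2ccc(Cl)c3cc[nH]c23)cc1` keeps the core of compound 3 and carries cyano in place of nitro on an aromatic carbon, para to a large group: cyano in place of nitro on an aromatic carbon. For the measured compounds named here, no compound with cyano has been measured, so this exchange has no direct precedent here. The closest evidence is the other exchanges at the same place. Going from chloro to nitro gave a 1.1-fold lower number from compound 2 to compound 3 (0.03 log units; within the scatter), while leaving methoxy gave the large steps of an 11-fold higher number from compound 1 to compound 2 (1.02 log units; beyond the scatter) and a 9.9-fold higher number from compound 1 to compound 3 (1.00 log units; beyond the scatter). Only compound 1 goes against the agreement of the other two, and cyano does not resemble its methoxy group in name or count. No step beyond the scatter is therefore expected in this assay. The expected change is a 1.1-fold lower number from compound 3 to compound 4 (0.06 log units; within the scatter), and this is only an estimate. Compound 4 is estimated at 8 ug/mL, with an expected range from 3 ug/mL to 20 ug/mL.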

Compound 4, half-maximal inhibitory concentration: 15 ug/mL
For compound 4 the middle estimate is 1.9-fold (0.27 log units) below the measured one, within the range that was stated.
By their numbers in this assay, from the lowest: compound 1; then compounds 3, 2 and 4 (each within the scatter of the next).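

In this assay, cyano at this place, on an aromatic carbon para to a large group, cannot be told apart from the two groups already tried there, with a 1.6-fold higher number from compound 3 to compound 4 (0.22 log units; within the scatter) and a 1.5-fold higher number from compound 2 to compound 4 (0.19 log units; within the scatter). The separation of compound 1 now holds against a third group, with a 16-fold higher number from compound 1 to compound 4 (1.21 log units; beyond the scatter), so among the four compounds shown, nitro, chloro and cyano form one level and compound 1, with its methoxy group, is the only one that goes against it. Nothing given here bears on why this exchange leaves the number level or why methoxy alone stands apart.

The compounds shown leave open whether the lower number belongs to methoxy alone or would also be found with a hydroxyl, an ethoxy group or an amine at this place. They also leave open whether the same order of groups would hold if the chloro on the shared core gave way to another group, such as a methyl group.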